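Swapping the Benzyl Substituent in a Urea and Thiourea Series

A few compounds are considered here, and "the series" means these few. Any claim that something is new, unique, unknown or untested is made for them only; others in the source may bear on it.

Compound 1, `Cc1ccc(NC(=S)NC(=O)c2ccc(OCc3cccc(Cl)c3)cc2)cc1-c1nc2ccccc2[nH]1`, gives 43300 nM in a functional assay on MNK45 cells (Homo sapiens) for inhibition, read by MTT assay, with a stated time of 48 h; on this read-out higher numbers stand for weaker inhibition and lower numbers for stronger inhibition.
Compound 2, `Cc1ccc(NC(=S)NC(=O)c2ccc(OCc3ccc(C(F)(F)F)cc3)cc2)cc1-c1nc2ccccc2[nH]1`, gives 10200 nM in this assay.
Compound 3, `Cc1ccc(NC(=O)NC(=O)c2ccc(OCc3cccc(Cl)c3)cc2)cc1-c1nc2ccccc2[nH]1`, gives 28000 nM in this assay.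

Compound 2 differs from compound 1 by 4-(trifluoromethyl)phenyl in place of 3-chlorophenyl on a saturated chain carbon bound to an oxygen on an aromatic ring, and this change produced a 4.2-fold lower number from compound 1 to compound 2 (0.63 log units; beyond the scatter). Compound 3 and compound 1 differ in their cores, and that difference is not broken down here. Compound 4, `Cc1ccc(NC(=O)NC(=O)c2ccc(OCc3ccc(C(F)(F)F)cc3)cc2)cc1-c1nc2ccccc2[nH]1`, is not yet measured in this assay; it differs from compound 3 by 4-(trifluoromethyl)phenyl in place of 3-chlorophenyl on a saturated chain carbon bound to an oxygen on an aromatic ring, the same change at the same place as in the first pair. A step of similar size is expected from compound 3 to compound 4, namely a 3.7-fold lower number from compound 3 to compound 4 (0.57 log units; beyond the scatter), because the earlier step of a 4.2-fold lower number from compound 1 to compound 2 (0.63 log units; beyond the scatter) lay beyond the scatter. Compound 4 is therefore estimated at 7500 nM in this assay, with a likely range of 3000 nM to 20000 nM.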

Compound 4, half-maximal inhibitory concentration: 16800 nM
For compound 4 the middle estimate is 2.2-fold (0.35 log units) below the measured one; the range from low to high includes it.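

In this assay, the swap from 3-chlorophenyl to 4-(trifluoromethyl)phenyl on the second core gives a 1.7-fold lower number from compound 3 to compound 4 (0.22 log units; within the scatter), so on this core the swap alone cannot be told apart from the ordinary spread of repeated measurements. Set beside the earlier step, the two results cannot be told apart either: the same change on two cores in this assay, a 4.2-fold lower number (0.63 log units; beyond the scatter) from compound 1 to compound 2 and a 1.7-fold lower number (0.22 log units; within the scatter) from compound 3 to compound 4, 2.5-fold (0.41 log units) apart, within the scatter of two such steps. These two pairs therefore do not show that the change keeps its size from one core to the other, and they do not show that the core alters it.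

The compounds shown leave open how other groups at this place would behave on either core. Examples are a phenyl ring carrying an amine or a carboxylic acid, or a longer chain in place of the benzyl group.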